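The compounds below may be only part of what the source reports. "The series", "measured", "known", "first", "only" and "open" are said of these compounds alone.

The measured compounds in a functional assay on HEK293 cells for agonist activity at D(4) dopamine receptor (Homo sapiens), read by FLIPR; on this read-out higher numbers stand for larger maximal responses and lower numbers for smaller maximal responses:
compound 1, `Cc1cccc(NC(=O)CN2CCC(c3ccc(O)cc3)CC2)c1`, which gives 60%;
compound 2, `Cc1cccc(NC(=O)CN2CCC(c3nccs3)CC2)c1`, which gives 62%;
compound 3, `Cc1cc(C)cc(C(=O)NCN2CCC(c3cccc[n+]3[O-])CC2)c1`, which gives 56%.

Compound 3 has the lowest of the three numbers in this assay, but the gaps to compound 1 and to compound 2 both lie within the scatter of the method, so the three compounds cannot be separated on this read-out. Within the data shown here, the only step between two measured compounds that differ in one place is a number 2 percentage points higher from compound 1 to compound 2 (within the scatter), where the change is 1,3-thiazol-2-yl in place of 4-hydroxyphenyl on a saturated ring carbon.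

Compound 4, `O=C(NCN1CCC(c2cccc[n+]2[O-])CC1)c1ccccc1`, is not yet measured. It differs from compound 3 as follows: phenyl in place of 3,5-dimethylphenyl on a carbonyl carbon. Among the measured compounds shown here, the one measured step concerns a different place in the molecule, the saturated ring carbon, and was within the scatter; nothing among the measured compounds speaks to a change on the carbonyl carbon. The step from compound 3 to compound 4 is therefore expected to be a number 1 percentage points lower from compound 3 to compound 4 (within the scatter), that is, no change beyond the scatter. Compound 4 is accordingly expected to give about 55% in this assay, within a range from 42% to 68%.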

Compound 4, largest response reached (reported as efficacy), in percent of the reference or control that the assay uses: 63%
Beside the measured number, compound 4's estimate is 8 percentage points below it; the measured number falls inside the stated range.
By their numbers in this assay, from the lowest: compounds 3, 1, 2 and 4 (each within the scatter of the next).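

In this assay, among these compounds, the carbonyl carbon now has a step of its own, which the earlier compounds could not give: a number 7 percentage points higher from compound 3 to compound 4 (within the scatter), with phenyl in place of 3,5-dimethylphenyl. The step lies within the scatter, so on this read-out the 3,5-dimethylphenyl group and the plain phenyl group cannot be told apart at this place, and a response in the same range as the other compounds remains when the smaller group, with 6 heavy atoms in place of 8, stands on the carbonyl carbon. No measurement among those available bears on why the two groups read alike.

The compounds shown leave open how far this tolerance reaches, since both groups at this place are six-membered aromatic rings of carbon only, and a saturated cyclohexyl group, a pyridyl ring or a phenyl carrying a carboxylic acid or an amine might read differently. They also leave open whether the same exchange on the carbonyl carbon would stay within the scatter with 1,3-thiazol-2-yl or 4-hydroxyphenyl on the saturated ring carbon.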